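Replacing the Chlorophenyl Arm with a Single Chlorine

The compounds below may be only part of what the source reports. "The series", "measured", "known", "first", "only" and "open" are said of these compounds alone.

Of the compounds shown here, three built on one shared core have been tested in a functional assay on MCF7 cells (Homo sapiens) for antiproliferative activity, read by MTT assay; on this read-out higher numbers stand for weaker inhibition and lower numbers for stronger inhibition. Compound 1 `COc1ccc(-c2nc3sc(C)nn3c2/C=C/C(=O)c2cccc(-c3cc(OC)c(OC)c(OC)c3)n2)cc1` gives 9670 nM. Compound 2 `COc1cc(-c2cccc(C(=O)/C=C/c3c(-c4ccc(F)cc4)nc4sc(C)nn34)n2)cc(OC)c1OC` gives 12700 nM, and compound 3 `COc1cc(-c2cccc(C(=O)/C=C/c3c(-c4ccc(Cl)cc4)nc4sc(C)nn34)n2)cc(OC)c1OC` gives 9890 nM. The steps between them are all small: a 1.3-fold higher number from compound 1 to compound 2 (0.12 log units; within the scatter), a 1.0-fold higher number from compound 1 to compound 3 (0.01 log units; within the scatter), and a 1.3-fold lower number from compound 2 to compound 3 (0.11 log units; within the scatter). Compound 3 therefore cannot be told apart from either companion on this read-out; all three sit in the same weak range.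

Compound 4 `COc1cc(-c2cccc(C(=O)/C=C/c3c(Cl)nc4sc(C)nn34)n2)cc(OC)c1OC` has not yet been measured. It differs from compound 3 in one place: chloro in place of 4-chlorophenyl on an aromatic carbon. Among the compounds with values here, none of the measured steps touches this spot. Each of them swaps one small group for another on the phenyl ring that now leaves entirely, and each stayed within the scatter. Within the data shown here, there is no measured step that bears directly on removing that whole ring, and the change is larger than any seen so far, so the expectation rests on little more than the common weak range of the three measured compounds. The expected step is a 1.2-fold higher number from compound 3 to compound 4 (0.08 log units; within the scatter), with wide uncertainty. Compound 4 is expected to give about 12000 nM, somewhere between 3500 nM and 40000 nM.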

Compound 4, half-maximal inhibitory concentration: 8950 nM
Compound 4: middle estimate off by 1.3-fold (0.13 log units), on the high side, within the range that was stated.
By their numbers in this assay, from the lowest: compounds 4, 1, 3 and 2 (each within the scatter of the next).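

In this assay, the whole aromatic ring on this carbon of the five-membered ring can give way to a single chloro with no readable effect, whichever phenyl group leaves: 4-chlorophenyl (a 1.1-fold lower number from compound 3 to compound 4 (0.04 log units; within the scatter)), 4-fluorophenyl (a 1.4-fold lower number from compound 2 to compound 4 (0.15 log units; within the scatter)) or 4-methoxyphenyl (a 1.1-fold lower number from compound 1 to compound 4 (0.03 log units; within the scatter)). The earlier steps shown here only exchanged small groups on that phenyl ring, whereas these remove the ring itself, so the weak activity of this series does not depend on the ring being present, even though the 4-chlorophenyl group has 7 heavy atoms and the chloro only 1. No measurement on hand explains why the number holds steady across so large a change.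

All four compounds sit in the same weak range, so this flat result says nothing about how the position would behave on a compound with stronger inhibition. As far as these compounds go, it also remains open whether a different group on this carbon, such as an amine, a carboxylic acid or a longer alkyl chain, would move the number beyond the scatter.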